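Swapping a Cyclohexyl Amide for a Chloropyridinyl Amide

The source may hold more compounds than are shown below. What is called first, only, known or untested is meant among the compounds shown, and "the series" means these compounds.

Two compounds carry the same core and differ only in the group on the amide nitrogen. Going by the values given here, compound 1 `Cc1noc(C)c1-c1cnc(N)c(Oc2ccc(C(=O)NC3CCCCC3)cc2)n1` holds the only actual number here: in a functional assay on HepG2 cells (Homo sapiens) for inhibition, read by MTT assay, with a stated time of 72 h (on this read-out higher numbers stand for weaker inhibition and lower numbers for stronger inhibition), compound 1 gives 5420 nM. Compound 2 `Cc1noc(C)c1-c1cnc(N)c(Oc2ccc(C(=O)Nc3ccccc3Cl)cc2)n1` is measured only as a limit of this assay, > 100000 nM, so its true value is not known. Among the compounds with values here, their step of an at least 18-fold higher number from compound 1 to compound 2 (1.26 log units; beyond the scatter) is the one measured change and it runs to weaker inhibition, reaching (the limit of > 100000 nM in this assay, at which 1 of the 2 values shown sits).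

Compound 3 `Cc1noc(C)c1-c1cnc(N)c(Oc2ccc(C(=O)Nc3cc(Cl)ccn3)cc2)n1` differs from compound 1 by 4-chloropyridin-2-yl in place of cyclohexyl on an amide-type nitrogen. Like the change to compound 2, this puts a chlorinated aromatic ring where cyclohexyl stood, and that single measured step was large and toward weaker inhibition. A large weakening is therefore expected for compound 3, a 7.4-fold higher number from compound 1 to compound 3 (0.87 log units; beyond the scatter), with a fair chance that this assay again reports only a limit. The estimate for compound 3 is 40000 nM, within a range from 8000 nM to 150000 nM.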

Compound 3, half-maximal inhibitory concentration: > 100000 nM
Compound 3 gave a limit, no number (the forecaster's own chance of this, stated with the estimate: 45%); middle value at least 2.5-fold (0.39 log units) away from the limit.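

In this assay, a second chlorinated aromatic ring in place of cyclohexyl on the amide-type nitrogen again moves strongly toward weaker inhibition, with an at least 18-fold higher number from compound 1 to compound 3 (1.26 log units; beyond the scatter). Compound 3 gives > 100000 nM, which is a limit of the assay and not a number. So the large loss seen with 2-chlorophenyl also appears with 4-chloropyridin-2-yl, whose ring carries a nitrogen atom and a hydrogen-bond acceptor, and compound 1 remains the only compound here with a measured number: the limit of > 100000 nM in this assay, at which 2 of the 3 values shown sit.

With a limit on each side, the step between compound 2 and compound 3 cannot be read, so these two rings cannot be ranked against each other. Still open, as far as these compounds go, is whether a plain phenyl, a cyclopentyl or a longer carbon chain on this nitrogen would give a measurable value.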